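The compounds below may be only part of what the source reports. "The series", "measured", "known", "first", "only" and "open" are said of these compounds alone.

Among the measured compounds shown here, in a functional assay on SH-SY5Y cells (Homo sapiens) for antiproliferative activity, read by MTT assay, with a stated time of 48 h (a higher number here means a weaker inhibitor of growth, a lower number a stronger inhibitor of growth), compound 3 `COc1ccc(N(C)c2nc(Cl)nc3c2ncn3C)cc1` gives 3400 nM, the only true number so far. Compound 1 `COc1ccc(N(C)c2ncnc3c2ncn3C)cc1` stands at > 100000 nM, a limit of the assay. Compound 2 `COc1ccc(N(C)c2nc(Cl)nc3[nH]cnc23)cc1` stands at > 100000 nM, also a limit.

Compound 4 `COc1ccc(Cn2cnc3c(N(C)c4ccc(OC)cc4)nc(Cl)nc32)cc1` carries 4-methoxyphenyl in place of hydrogen on a saturated chain carbon bound to an aromatic nitrogen. The same change reads as methyl to 4-methoxybenzyl. The closest measured change is the large at least 29-fold lower number from compound 2 to compound 3 (1.46 log units; beyond the scatter), which installs the methyl that compound 4 extends. The large at least 29-fold lower number from compound 1 to compound 3 (1.46 log units; beyond the scatter) concerns the chloro that compound 4 retains. Neither step tests a group of this size, so only a moderate move towards weaker growth inhibition is expected. The expected step is a 1.8-fold higher number from compound 3 to compound 4 (0.25 log units; within the scatter). Compound 4 is estimated at 6000 nM, within a range of 1200 nM to 30000 nM.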

Compound 4, concentration for 50% growth inhibition: 31000 nM
The estimate for compound 4 lay 5.2-fold (0.71 log units) below the measured number, outside the stated range (above it).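

Extending methyl to 4-methoxybenzyl on the aromatic nitrogen gives back part of what methyl gained, with a 9.1-fold higher number from compound 3 to compound 4 (0.96 log units; beyond the scatter), so the effect of filling this position does not grow with the size of the group. A substituent as large as 4-methoxybenzyl still retains an advantage over hydrogen on that nitrogen, with an at least 3.2-fold lower number from compound 2 to compound 4 (0.50 log units; beyond the scatter). That step is only a bound, since compound 2 stands at a limit of the assay: the limit of > 100000 nM in this assay, at which 2 of the 4 values shown sit.

Going by these compounds, whether ethyl or a longer chain would match methyl remains open. So does whether unsubstituted benzyl or a chain ending in an amine would behave like 4-methoxybenzyl.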